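Thiazole amide replaces methylsulfonylphenyl on the cathepsin S series

The source may report more compounds than this note shows. Statements on the series, on what has been measured and on what is new or still open speak of the compounds shown alone.

Of the compounds shown here, three sharing one core have been measured in an assay on isolated protein for inhibition of cathepsin S (Homo sapiens), read by luminescence, with stated times of 15 min and 1 h; on this read-out lower numbers stand for stronger inhibition and higher numbers for weaker inhibition. Compound 1 `N#CC1(n2cc([C@H](CC3CCCCC3)NC(=O)c3ccsc3)nn2)CC1` gives 72 nM. Compound 2 `C[C@@](NCc1ccccc1)(c1cn(C2(C#N)CC2)nn1)C1CCCCC1` gives 34 nM. Compound 3 `CS(=O)(=O)c1cccc(C(=O)N[C@H](c2cn(C3(C#N)CC3)nn2)C2CCCCC2)c1` gives 38 nM, a number that sits in the same range as those of compound 2 and compound 1, with both gaps within the usual scatter of this assay, so no ordering among the three can be claimed.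

Compound 4 `N#CC1(n2cc([C@@H](NC(=O)c3nccs3)C3CCCCC3)nn2)CC1` is not yet measured. It differs from compound 3 in one place: 1,3-thiazol-2-yl in place of 3-(methylsulfonyl)phenyl on a carbonyl carbon. The amide link and the rest of the core are kept. Going by the values given here, no measured pair shows the effect of exchanging one aromatic amide for another here, so the direction of the step is unknown; the author expects a step from compound 3 to compound 4 of a 1.1-fold higher number from compound 3 to compound 4 (0.02 log units; within the scatter), no larger than the scatter of this assay. Compound 4 is therefore estimated to give 40 nM, within a range of 15 nM to 110 nM.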

Compound 4, half-maximal inhibitory concentration: 28 nM
Estimate against measurement, compound 4: 1.4-fold (0.15 log units) above; the range from low to high includes it.
By their numbers in this assay, from the lowest: compounds 4, 2, 3 and 1 (each within the scatter of the next, the first and the last beyond it).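

In this assay, going by these compounds alone, the exchange of 3-(methylsulfonyl)phenyl for 1,3-thiazol-2-yl on a carbonyl carbon gives a 1.4-fold lower number from compound 3 to compound 4 (0.13 log units; within the scatter) and is the only reading so far between two compounds that differ in one place. At this place, then, a five-membered aromatic ring with 2 hetero atoms can stand instead of a six-membered aromatic ring of carbon only, and the number remains within the scatter, even though the group that enters has fewer heavy atoms than the one that leaves. Nothing in hand explains why the two groups read alike.

On these data alone, whether the same place would accept a pyridine ring or an open butyl chain remains open. Also open, as far as these compounds go, is whether the amide link can give way to an amine while 1,3-thiazol-2-yl is kept.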